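Isobutyl for 4-fluorophenyl on the amide nitrogen

This account rests on a few compounds, and the source may have more. Where it says the series, first, only, none or still open, it means among the compounds named here.

In a functional assay on BaF3 cells (Mus musculus) for antiproliferative activity, read by CCK-8 assay and cell counting, with a stated time of 76 h (a lower number here means a stronger inhibitor, a higher number a weaker inhibitor), compound 3 `COc1cc2nccc(Oc3ccc(Nc4nn(C)cc4C(=O)Nc4ccc(F)cc4)cc3)c2cc1C(N)=O` gives 3060 nM and compound 1 `COc1cc2nccc(Oc3ccc(Nc4nn(C)cc4C(=O)N4CCCCC4)cc3)c2cc1C(N)=O` gives 5650 nM in the same series. The gap between them is a 1.8-fold lower number from compound 1 to compound 3 (0.27 log units; within the scatter) and so does not separate the two. Compound 2 `COc1cc2nccc(Oc3ccc(Nc4nn(C)cc4C(=O)NCC4CCCO4)cc3)c2cc1C(N)=O` gives > 10000 nM as a limit of the assay and not a number.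

Compound 4 `COc1cc2nccc(Oc3ccc(Nc4nn(C)cc4C(=O)NCC(C)C)cc3)c2cc1C(N)=O` has isobutyl in place of 4-fluorophenyl on an amide-type nitrogen with the rest of the structure unchanged. The closest measured precedent is compound 2, which also lacks 4-fluorophenyl on that nitrogen. Its step, an at least 3.2-fold lower number from compound 2 to compound 3 (0.51 log units; beyond the scatter) here, sets the direction, while the step to compound 1 keeps the expected size modest. A higher number than for compound 3 is therefore expected, with a move near the edge of the scatter. The estimated step is a 2.0-fold higher number from compound 3 to compound 4 (0.29 log units; within the scatter) in this assay for this change. The expected value for compound 4 is 6000 nM with an estimated range of 2500 nM to 10000 nM as the working figure.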

Compound 4, half-maximal inhibitory concentration: > 10000 nM
Compound 4 ended at the assay's limit; the forecaster's own chance of this, stated with the estimate: 25%; at least 1.6-fold (0.22 log units) between middle value and limit.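

In this assay compound 4, like compound 2, reads as a limit of the assay and not a number: the limit of > 10000 nM in this assay, at which 2 of the 4 values shown sit.

On the amide-type nitrogen, isobutyl in place of 4-fluorophenyl gives an at least 3.2-fold higher number from compound 3 to compound 4 (0.51 log units; beyond the scatter), so a second group without the aromatic ring, this one with no ring at all, sits beyond the scatter from compound 3. Compound 1, which also lacks that aromatic ring, goes against any rule that the ring alone decides, and an at least 1.7-fold higher number from compound 1 to compound 4 (0.24 log units; that floor lies within the scatter) does not separate compound 4 from it.

The step between compound 2 and compound 4 cannot be read, since both stand at the limit. Going by these compounds, whether a plain phenyl, a benzyl or a longer chain on that nitrogen would give a measurable number stays open.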